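The source may report more compounds than this note shows. Statements on the series, on what has been measured and on what is new or still open speak of the compounds shown alone.

Compound 1 `CNc1ncc2c(-c3ccc(N4CCNCC4)nc3)nn(CC3OCCO3)c2n1` gives 6200 nM in an assay for inhibition of tyrosine-protein kinase Mer (Homo sapiens), read by 33P incorporation, in the presence of a further agent that is not named here; on this read-out higher numbers stand for weaker inhibition and lower numbers for stronger inhibition. Compound 2 `CNc1ncc2c(-c3ccc(N4CCNCC4)nc3)nn(Cc3cn(Cc4ccccc4)nn3)c2n1` gives 2300 nM in this assay, the lowest of the two numbers seen so far, with the step of a 2.7-fold lower number from compound 1 to compound 2 (0.43 log units; beyond the scatter) standing behind it. Compound 3 `CNc1ncc2c(-c3ccc(N4CCN(C(=O)C(C)(C)C)CC4)nc3)nn(Cc3cn(Cc4ccccc4)nn3)c2n1` differs from compound 2 by (tert-butyl)carbonyl in place of hydrogen on an amine nitrogen in a ring. Within the data shown here, no measured step touches this amine nitrogen in a ring: the only step in hand, a 2.7-fold lower number from compound 1 to compound 2 (0.43 log units; beyond the scatter), alters the group on the saturated chain carbon bound to an aromatic nitrogen, and so gives no guide here. Compound 3 is therefore expected to show a step of a 1.3-fold higher number from compound 2 to compound 3 (0.12 log units; within the scatter), no larger than the scatter, to about 3000 nM, somewhere between 1000 nM and 10000 nM.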

Compound 3, half-maximal inhibitory concentration: 5400 nM
The estimate for compound 3 lay 1.8-fold (0.26 log units) below the measured number; the range from low to high includes it.
By their numbers in this assay, from the lowest: compound 2; then compounds 3 and 1 (each within the scatter of the next).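

The amine nitrogen in the six-membered ring now has its first measured step: going from piperazin-1-yl to 4-((tert-butyl)carbonyl)piperazin-1-yl gives a 2.3-fold higher number from compound 2 to compound 3 (0.37 log units; beyond the scatter) in this assay and so shows that this position responds to the change. The step is modest, even though the entering group brings 6 heavy atoms. No measured evidence explains this rise.

Going by these compounds, whether a smaller acetyl or methyl group on the same nitrogen would shift the number as far remains open. So does whether the (tert-butyl)carbonyl group would act alike alongside the 1,3-dioxolan-2-yl group of compound 1.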